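Aryl for alkyl on the hydroxyl-bearing carbon of compound 1

The compounds below may be only part of what the source reports. "The series", "measured", "known", "first", "only" and "open" are said of these compounds alone.

The series shares a core carrying a chlorophenyl methylamide and a tetrazole, with a hydroxy acyl group on the ring nitrogen. Compound 1 `CCCC[C@@H](O)C(=O)N1C[C@H]2C[C@H]2[C@H]1C(=O)NCc1cc(Cl)ccc1-n1cnnn1` carries a butyl group on the carbon that bears the hydroxyl; in an ADME assay on liver for metabolic stability, with Liver microsome (Homo sapiens) as the target, read by LC-MS, using microsomes (on this read-out higher numbers stand for fast clearance and lower numbers for slow clearance), compound 1 gives 32 mL.min-1.g-1. This is the lowest of the two numbers reported, the nearest neighbour being compound 3 `CC(C)(C)[C@@H](O)C(=O)N1[C@H](C(=O)NCc2cc(Cl)ccc2-n2cnnn2)C[C@@H]2C[C@@H]21`, which in this assay gives 75 mL.min-1.g-1, a gap beyond the usual scatter. Compound 2 `CC(C)(C)[C@@H](O)C(=O)N1CS(=O)(=O)C[C@H]1C(=O)NCc1cc(Cl)ccc1-n1cnnn1` reaches only a limit of the assay, (the limit of < 12 mL.min-1.g-1 in this assay, at which 1 of the 3 values shown sits), so no number is known for compound 2 in this assay, which gives < 12 mL.min-1.g-1.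

Compound 4 `O=C(NCc1cc(Cl)ccc1-n1cnnn1)[C@@H]1[C@@H]2C[C@@H]2CN1C(=O)[C@H](O)c1ccccc1F` differs from compound 1 in one place: 2-fluorophenyl in place of butyl on a saturated chain carbon bound to a carbonyl carbon and an oxygen on a saturated carbon. Among the compounds with values here, no measured pair here isolates this change, so the direction can only be guessed. The expected step in this assay is small, a 1.1-fold lower number from compound 1 to compound 4 (0.06 log units; within the scatter), within the scatter of the method. Compound 4 is therefore expected to give about 28 mL.min-1.g-1, between 10 mL.min-1.g-1 and 80 mL.min-1.g-1.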

Compound 4, intrinsic clearance in microsomes: < 12 mL.min-1.g-1
Compound 4 gave a limit, no number; the forecaster's own chance of this, stated with the estimate: 15%; middle value at least 2.3-fold (0.36 log units) away from the limit.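

Among the compounds shown, this is the only step between two that differ in one place: compound 2 and compound 3 each differ from compound 1 in more than one place, so neither could show how this position responds on its own. Putting 2-fluorophenyl in place of butyl here gives, in this assay, an at least 2.6-fold lower number from compound 1 to compound 4 (0.42 log units; beyond the scatter), so clearance responds to this change and the aromatic ring brings no rise in it. The true size of the step remains unknown, as compound 4 stands at a limit of the assay and not at a number: the limit of < 12 mL.min-1.g-1 in this assay, at which 2 of the 4 values shown sit.

From the compounds shown here alone, whether plain phenyl, a longer chain or a carboxylic acid at this position would give a similar read-out remains open. So does whether the same change would carry over to the cores of compound 2 and compound 3.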